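A few compounds are considered here, and "the series" means these few. Any claim that something is new, unique, unknown or untested is made for them only; others in the source may bear on it.

Working notes on a small set of sulfonyl indole-type compounds sharing one core, read in an assay on HeLa cells for displacement of a labelled ligand from 5-hydroxytryptamine receptor 6 (Homo sapiens); a higher number here means a weaker inhibitor, a lower number a stronger inhibitor.

Compound 1 `O=S(=O)(c1ccccc1F)c1cn(C2CCNC2)c2ncccc12` gives 2 nM in this assay. Compound 2 `CCN1CCC(n2cc(S(=O)(=O)c3cccc(F)c3)c3cccnc32)C1` differs from compound 1 in more than one place. Compound 2 gives 8.3 nM. Compound 3 `O=S(=O)(C1=C(Cl)NC2SC=CN12)c1cn(C2CCNC2)c2ncccc12` gives 1 nM and so has the lowest number of the three; its gap to compound 1 lies within the scatter, while its gap to compound 2 lies beyond it. Going by the values given here, no pair among the measured compounds differs in a single place, so no isolated step is available.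

Compound 4 `CCN1CCC(n2cc(S(=O)(=O)C3=C(Cl)NC4SC=CN34)c3cccnc32)C1` is not yet measured. Relative to compound 3 the change is ethyl in place of hydrogen on an amine nitrogen in a ring. The same kind of substitution on the ring nitrogen is present in compound 2 versus compound 1, but there it is accompanied by a second change, so it cannot be read cleanly. The expectation for compound 4 is a small loss, estimated as a 3.0-fold higher number from compound 3 to compound 4 (0.48 log units; beyond the scatter), which may not clear the scatter. Compound 4 is estimated at 3 nM, within 1 nM to 9 nM.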

Compound 4, inhibition constant: 1.4 nM
The estimate for compound 4 lay 2.1-fold (0.33 log units) above the measured number; the measured number falls inside the stated range.
By their numbers in this assay, from the lowest: compounds 3, 4 and 1 (each within the scatter of the next); then compound 2.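

In this assay, going by these compounds alone, the step of a 1.4-fold higher number from compound 3 to compound 4 (0.15 log units; within the scatter) gives the first clean reading of ethyl in place of hydrogen on the amine nitrogen in a ring, a substitution that the pair compound 1 and compound 2 could not isolate. With the group on the sulfonyl sulfur of compound 3 in place, pyrrolidin-3-yl and 1-ethylpyrrolidin-3-yl cannot be told apart in this read-out. With 1-ethylpyrrolidin-3-yl held constant, the sulfonyl group can now be read on its own: the step of a 5.9-fold lower number from compound 2 to compound 4 (0.77 log units; beyond the scatter) comes with the group of 9 heavy atoms in place of the group of 7 heavy atoms on the sulfonyl sulfur, and it lies beyond the scatter. No measurement shown gives a cause for either step. Still open, as far as these compounds go, is whether a longer chain such as propyl or a benzyl group on that ring nitrogen would keep the number in this range.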